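Replacing 3-chlorobenzyl with 3,5-dimethoxyphenyl on the shared core

The source may hold more compounds than are shown below. What is called first, only, known or untested is meant among the compounds shown, and "the series" means these compounds.

In a functional assay on HCC827 cells (Homo sapiens) for inhibition, read by fluorescence, with a stated time of 72 h (a lower number here means a stronger inhibitor of growth, a higher number a weaker inhibitor of growth), compound 2 `CC(C)CCn1cnc2c(NCc3cccc(Cl)c3)nc(N[C@H]3CC[C@H](N)CC3)nc21` gives 16700 nM and compound 1 `COc1ccc(Nc2nc(N[C@H]3CC[C@H](N)CC3)nc3c2ncn3CCC(C)C)c(OC)c1` gives 32900 nM with the two values within the scatter of each other. Compound 3 `COc1cc(Nc2nc(N[C@H]3CC[C@H](N)CC3)nc3c2ncn3CCC(C)C)cc(OC)c1` carries 3,5-dimethoxyphenyl in place of 3-chlorobenzyl on a nitrogen on an aromatic ring. For the measured compounds named here, the only measured step bearing on this change (a 2.0-fold lower number from compound 1 to compound 2 (0.29 log units; within the scatter)) joins 2,4-dimethoxyphenyl and 3-chlorobenzyl at that nitrogen and stays within the scatter, so no shift beyond the scatter is expected in this assay here. The expected step (a 1.5-fold higher number from compound 2 to compound 3 (0.18 log units; within the scatter)) is correspondingly small. Compound 3 is estimated at 25000 nM with 10000 nM to 60000 nM as the expected range.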

Compound 3, concentration for 50% growth inhibition: 11200 nM
The estimate for compound 3 lay 2.2-fold (0.35 log units) above the measured number, within the range that was stated.
By their numbers in this assay, from the lowest: compounds 3, 2 and 1 (each within the scatter of the next, the first and the last beyond it).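

In this assay, for the compounds shown here, the two dimethoxyphenyl patterns at this nitrogen now separate: 3,5-dimethoxyphenyl in place of 2,4-dimethoxyphenyl gives the only step of the three beyond the scatter, though a modest one (a 2.9-fold lower number from compound 1 to compound 3 (0.47 log units; beyond the scatter)). Against 3-chlorobenzyl, the same group gives a step within the scatter (a 1.5-fold lower number from compound 2 to compound 3 (0.17 log units; within the scatter)), so compound 2 and compound 3 cannot be ordered. No evidence given here accounts for the difference between the two dimethoxyphenyl patterns. As far as these compounds go, whether a plain phenyl or a 3-aminophenyl on this nitrogen would lower the number further remains open.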